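The source may hold more compounds than are shown below. What is called first, only, known or untested is meant among the compounds shown, and "the series" means these compounds.

Values in a functional assay on CCRF-CEM cells for antagonist activity at C-X-C chemokine receptor type 4 (Homo sapiens), read by calcium flux, with stated times of 25 min and 90 s (on this read-out lower numbers stand for stronger inhibition and higher numbers for weaker inhibition), so far:
compound 1 `CN1CC[C@H]2CN(c3cccc4c3C[C@H](CN(C)[C@H]3CCCc5cccnc53)NC4)C[C@H]21`: 11.4 nM
compound 2 `CN1C[C@@H]2CN(c3cccc4c3C[C@H](CN(C)[C@H]3CCCc5cccnc53)NC4)C[C@@H]2C1`: 9.56 nM
compound 3 `CN(C)C1CCN(c2cccc3c2C[C@H](CN(C)[C@H]2CCCc4cccnc42)NC3)CC1`: 35.9 nM

Compound 1 stands second highest of the three numbers. Its nearest neighbour is compound 2, with a 1.2-fold lower number from compound 1 to compound 2 (0.08 log units; within the scatter), so the two cannot be ordered. The furthest is compound 3, with a 3.1-fold higher number from compound 1 to compound 3 (0.50 log units; beyond the scatter), a modest rise that is beyond the scatter.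

Compound 4 `CN(C[C@H]1Cc2c(cccc2N2CCC(N)CC2)CN1)[C@H]1CCCc2cccnc21` differs from compound 1 by a group of 7 heavy atoms (5 carbon, 2 nitrogen; one six-membered non-aromatic ring with 1 hetero atom) in place of a group of 9 heavy atoms (7 carbon, 2 nitrogen; 2 five-membered non-aromatic rings with 1 hetero atom each), on an aromatic carbon

For the measured compounds named here, two measured steps bear on this change. Both a 3.1-fold higher number from compound 1 to compound 3 (0.50 log units; beyond the scatter) and a 3.8-fold higher number from compound 2 to compound 3 (0.57 log units; beyond the scatter) replace the pair of five-membered non-aromatic rings with a single six-membered non-aromatic ring holding one hetero atom on the same aromatic carbon, and both raise the number beyond the scatter. Going by the values given here, compound 4 also carries a six-membered ring with one hetero atom at that position, but as 4-aminopiperidin-1-yl, which is smaller than the group in compound 3 and brings one hydrogen-bond donor; no measured pair covers that exact exchange. The expectation is therefore a modest rise of about the size seen in a 3.1-fold higher number from compound 1 to compound 3 (0.50 log units; beyond the scatter), with wider uncertainty than that step alone would give. For compound 4 the estimate in this assay is 30 nM, expected between 12 nM and 80 nM. This estimate corresponds to an expected 2.6-fold higher number from compound 1 to compound 4 (0.42 log units; beyond the scatter).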

Compound 4, half-maximal inhibitory concentration: 33.4 nM
For compound 4 the middle estimate is 1.1-fold (0.05 log units) below the measured one; measured number inside the range.
By their numbers in this assay, from the lowest: compounds 2 and 1 (each within the scatter of the next); then compounds 4 and 3 (each within the scatter of the next).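

In this assay, the 4-aminopiperidin-1-yl group on the aromatic carbon costs about as much as the six-membered ring already seen in compound 3, with a 2.9-fold higher number from compound 1 to compound 4 (0.47 log units; beyond the scatter) and a 3.5-fold higher number from compound 2 to compound 4 (0.54 log units; beyond the scatter), so the loss against the groups with two five-membered rings now holds for two different substituents on the six-membered ring. For the compounds shown here, the exchange on the saturated ring carbon is read directly for the first time: a 1.1-fold lower number from compound 3 to compound 4 (0.03 log units; within the scatter), so amino and dimethylamino cannot be told apart in this assay, and in these two compounds the read-out does not follow the substituent on that ring carbon. Nothing available accounts for the higher numbers of the six-membered-ring compounds or for the lack of separation of amino from dimethylamino.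

Open, on these data alone, is whether a hydroxyl or a carboxylic acid on that saturated ring carbon would stay level with amino and dimethylamino, or whether only amines do so. Also open, as far as these compounds go, is whether a piperazine ring on the aromatic carbon would read with the six-membered-ring compounds or with those carrying two five-membered rings.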